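The compounds below may be only part of what the source reports. "The series", "measured", "known", "first", "only" and "open" are said of these compounds alone.

Three members of the series have been measured in a functional assay on A549 cells (Homo sapiens) for cytotoxicity, read by MTT assay, with a stated time of 48 h; a lower number here means a stronger inhibitor, a higher number a weaker inhibitor. Compound 1 `COc1cc(-c2nnc3n2NC(c2ccco2)C(C(=O)c2ccc(Br)cc2)S3)cc(OC)c1OC` gives 42100 nM; compound 2 `COc1cc(-c2nnc3n2NC(c2ccco2)C(C(=O)c2ccc(F)cc2)S3)cc(OC)c1OC` gives 53700 nM; compound 3 `COc1cc(-c2nnc3n2NC(c2cccs2)C(C(=O)c2ccc(F)cc2)S3)cc(OC)c1OC` gives 45000 nM. Compound 2 carries the highest of the three numbers, yet its steps to compound 3 and to compound 1 both fall within the scatter, so no ranking can be read from them. The recorded steps confirm this: a 1.3-fold higher number from compound 1 to compound 2 (0.11 log units; within the scatter), and a 1.2-fold lower number from compound 2 to compound 3 (0.08 log units; within the scatter).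

Compound 4 `COc1cc(-c2nnc3n2NC(c2ccco2)C(C(=O)c2ccc(F)c(F)c2)S3)cc(OC)c1OC` has not yet been measured in this assay. It differs from compound 2 by fluoro in place of hydrogen on an aromatic carbon. Going by the values given here, the one earlier change on the same ring, a 1.3-fold higher number from compound 1 to compound 2 (0.11 log units; within the scatter), stayed within the scatter, and the change at the saturated ring carbon did as well, so a second fluoro on that ring is expected to shift the number no further than the scatter, in no settled direction. The expected step is a 1.1-fold lower number from compound 2 to compound 4 (0.03 log units; within the scatter). For compound 4 the estimate is 50000 nM, with a range from 25000 nM to 100000 nM.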

Compound 4, half-maximal inhibitory concentration: 93700 nM
The estimate for compound 4 lay 1.9-fold (0.27 log units) below the measured number; low and high end bracket the measured number.
By their numbers in this assay, from the lowest: compounds 1, 3, 2 and 4 (each within the scatter of the next, the first and the last beyond it).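

In this assay, a fluoro placed ortho to a fluoro group and meta to a large group gives a 1.7-fold higher number from compound 2 to compound 4 (0.24 log units; within the scatter), so this single addition to the 4-fluorophenyl ring still cannot be read as a real change. Going by these compounds alone, the 3,4-difluorophenyl group in place of 4-bromophenyl on the carbonyl carbon gives a 2.2-fold higher number from compound 1 to compound 4 (0.35 log units; beyond the scatter), the only step so far beyond the scatter, though modest, making compound 4 a weaker inhibitor than compound 1. Nothing available bears on why this step occurs.

Still open, from the compounds shown here alone, is whether this ring accepts anything other than halogens at these places, such as a methoxy group, an amine or a carboxylic acid. Also open, going by these compounds, is whether 3,4-difluorophenyl gives a similar number alongside thiophen-2-yl in place of furan-2-yl.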